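Working notes: methoxy in place of fluoro in compound 1

The source may hold more compounds than are shown below. What is called first, only, known or untested is meant among the compounds shown, and "the series" means these compounds.

Measured in a functional assay on MIA PaCa-2 cells (Homo sapiens) for cytotoxicity, read by WST assay, with a stated time of 24 h; a higher number here means a weaker inhibitor, a lower number a stronger inhibitor:
- compound 1 `COc1ccc2c(/C=C(\C#N)C(=O)c3c[nH]c4cc(F)ccc34)c[nH]c2c1` gives > 50000 nM, a limit
- compound 2 `COc1ccc2[nH]cc(/C=C(\C#N)C(=O)c3c[nH]c4ccccc34)c2c1` gives 21200 nM

Compound 1 gives > 50000 nM, which is a limit of the assay and not a number. For the measured compounds named here, compound 2 gives 21200 nM, the only true number so far.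

Compound 3 `COc1ccc2c(/C=C(\C#N)C(=O)c3c[nH]c4cc(OC)ccc34)c[nH]c2c1` is the next step from compound 1: methoxy in place of fluoro on an aromatic carbon. This places methoxy in place of fluoro on an aromatic carbon of a six-membered aromatic ring of carbon only.

Going by the values given here, no measured step covers this change, so no step beyond the scatter is expected in this assay, in either direction. The expected change is an at least 1.1-fold lower number from compound 1 to compound 3 (0.04 log units; that floor lies within the scatter). The expectation rests on compound 1 at > 50000 nM, which is a limit. For compound 3 the estimated value is 45000 nM, with an expected range from 18000 nM to 90000 nM.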

Compound 3, half-maximal inhibitory concentration: > 50000 nM
Compound 3 was reported as a limit (the forecaster's own chance of this, stated with the estimate: 60%); middle value at least 1.1-fold (0.04 log units) from the limit.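

In this assay, compound 1 and compound 3 both sit at a limit of the assay, so no step can be read between them: the limit of > 50000 nM in this assay, at which 2 of the 3 values shown sit.

The compounds shown leave open whether methoxy in place of fluoro on an aromatic carbon changes the read-out at all.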